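Swapping Methoxy for Dimethylamino on a Non-Toxic Side Chain

A few compounds are considered here, and "the series" means these few. Any claim that something is new, unique, unknown or untested is made for them only; others in the source may bear on it.

In an ADME assay on HepG2 2.2.15 cells (Homo sapiens) for cytotoxicity, read by MTT assay, with a stated time of 8 days (on this read-out lower numbers stand for higher toxicity in this test and higher numbers for lower toxicity in this test), compound 1 `COCCNc1nc(F)c(-c2nn(Cc3ccc(C#N)cc3)c(=O)c3ccccc23)cc1Cl` gives > 100000 nM, which is a limit and not a number. Compound 2 `COCCNc1ccc(-c2nn(Cc3ccc(C#N)cc3)c(=O)c3ccccc23)c(F)n1` gives > 100000 nM, likewise a limit. All the data therefore amount to the limit of > 100000 nM in this assay, at which 2 of the 2 values shown sit. Among the compounds with values here, the one measured step, a step that the two limits leave unreadable from compound 1 to compound 2, has no readable size and concerns a different place from the change considered here.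

Compound 3 `CN(C)CCNc1nc(F)c(-c2nn(Cc3ccc(C#N)cc3)c(=O)c3ccccc23)cc1Cl` keeps the core of compound 1 but turns the 2-methoxyethyl chain into a 2-(dimethylamino)ethyl chain: dimethylamino in place of methoxy on a saturated chain carbon, two bonds along the chain from a nitrogen on an aromatic ring. Within the data shown here, no measured step covers this exchange, so the expectation rests on the starting point of compound 1 at > 100000 nM and on the structural change alone. A modest shift towards higher toxicity in this assay is expected, although compound 3 may well stay at the limit too. The estimated step is an at least 1.6-fold lower number from compound 1 to compound 3 (0.22 log units; that floor lies within the scatter), and its size is uncertain because the reference is only a limit. Compound 3 is estimated at 60000 nM, with an expected range from 15000 nM to 150000 nM.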

Compound 3, half-maximal cytotoxic concentration: 9760 nM
Compound 3: the middle estimate sits 6.1-fold (0.79 log units) above what was measured, and the stated range ends above it.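

In this assay the exchange of methoxy for dimethylamino on a saturated chain carbon, two bonds along the chain from a nitrogen on an aromatic ring, gives an at least 10-fold lower number from compound 1 to compound 3 (1.01 log units; beyond the scatter) and so moves the read-out towards higher toxicity in this test. This is the first sign in the compounds shown that the read-out responds to this position, and compound 3 is the only one of them with a value that is a number rather than a limit. The step between compounds 1 and 2 cannot be read, and before compound 3 the data held nothing but a ceiling: the limit of > 100000 nM in this assay, at which 2 of the 3 values shown sit.

The compounds shown leave open whether another amine on the same chain, such as a pyrrolidine or a morpholine, or a longer chain ending in dimethylamino, would move the read-out as far, and whether a hydroxyl in the same place would leave it at the limit. They also leave open whether the same exchange would have a similar effect on the core of compound 2, which carries hydrogen in place of chloro.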